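Working notes: aryl substituent change from compound 2 to compound 4

The source may report more compounds than this note shows. Statements on the series, on what has been measured and on what is new or still open speak of the compounds shown alone.

Three compounds have numbers in a functional assay on HT-29 cells (Homo sapiens) for antiproliferative activity, read by sulforhodamine B assay, with a stated time of 48 h; a higher number here means a weaker inhibitor, a lower number a stronger inhibitor. Compound 1 `CCc1ccccc1NS(=O)(=O)c1ccc(N2CCNC2=O)cc1` gives 240 nM, compound 3 `CCc1cccc(NS(=O)(=O)c2ccc(N3CCNC3=O)cc2)c1` gives 110 nM, and compound 2 `CCCCc1ccc(NS(=O)(=O)c2ccc(N3CCNC3=O)cc2)cc1` gives 610 nM, the highest of the three. Within the data shown here, the one measured step, a 2.2-fold lower number from compound 1 to compound 3 (0.34 log units; beyond the scatter), concerns only where the ethyl sits. Compound 4 `COc1ccc(NS(=O)(=O)c2ccc(N3CCNC3=O)cc2)cc1` differs from compound 2 by methoxy in place of butyl on an aromatic carbon. Among the measured compounds shown here, no measured step exchanges the group itself at this place, so nothing bears directly on this change; the only guidance is that compound 2, carrying butyl, stands highest, while compound 1 and compound 3, carrying ethyl, stand lower. A modest downward step is therefore expected, a 1.5-fold lower number from compound 2 to compound 4 (0.18 log units; within the scatter), with wide uncertainty. Compound 4 is estimated at 400 nM, in the range 150 nM to 1200 nM.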

Compound 4, half-maximal inhibitory concentration: 800 nM
Compound 4: middle estimate off by 2.0-fold (0.30 log units), on the low side; low and high end bracket the measured number.
By their numbers in this assay, from the lowest: compound 3; then compound 1; then compounds 2 and 4 (each within the scatter of the next).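

In this assay, butyl and methoxy on this aromatic carbon are not told apart: a 1.3-fold higher number from compound 2 to compound 4 (0.12 log units; within the scatter). Both ethyl compounds stand lower, with a 7.3-fold higher number from compound 3 to compound 4 (0.86 log units; beyond the scatter) and a 3.3-fold higher number from compound 1 to compound 4 (0.52 log units; beyond the scatter), but each of these steps changes the group and its place together, so neither isolates one from the other. No supporting evidence bears on these differences.

As far as these compounds go, whether ethyl at this same place would stand with butyl and methoxy or with the two ethyl compounds remains open, as does the outcome for an amine or a carboxylic acid there.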